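The source may report more compounds than this note shows. Statements on the series, on what has been measured and on what is new or still open speak of the compounds shown alone.

Measured compounds in an ADME assay for permeability, using PAMPA, with a stated time of 30 min, at pH 7.4; on this read-out lower numbers stand for lower permeability and higher numbers for higher permeability:
- compound 1 `COc1ccc(F)cc1CNCCCNc1ccnc2cc(Cc3ccccc3)ccc12`: 23 10^-6 cm/s
- compound 2 `COc1ccc(F)cc1CNCCCNc1ccnc2cc(CC3CCCCC3)ccc12`: 23 10^-6 cm/s

Compound 2 stands level with compound 1 in this assay, the step of no change at the digits printed from compound 1 to compound 2 (within the scatter) lying within the scatter. Compound 3 `COc1ccc(F)cc1CNCCCNc1ccnc2cc(Oc3ccccc3OC)ccc12` is not yet measured. It differs from compound 2 in one place: 2-methoxyphenoxy in place of cyclohexylmethyl on an aromatic carbon. Going by the values given here, the only measured step, no change at the digits printed from compound 1 to compound 2 (within the scatter), swapped one carbon ring for another on the same carbon and left the read-out unchanged; no measured step covers the entry of an oxygen-linked group with two hydrogen-bond acceptors, so the data give no guide to its size or direction. Starting from compound 2, the expectation for compound 3 is at most a small step downward, a 1.3-fold lower number from compound 2 to compound 3 (0.11 log units; within the scatter), that may well fall within the scatter. Compound 3 is therefore estimated at 18 10^-6 cm/s, with a range from 9 10^-6 cm/s to 36 10^-6 cm/s.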

Compound 3, apparent permeability: 317 10^-6 cm/s
Compound 3: the middle estimate sits 18-fold (1.25 log units) below what was measured; measured number above the stated range.
By their numbers in this assay, from the lowest: compounds 1 and 2 (each within the scatter of the next); then compound 3.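

In this assay, this aromatic carbon turns out to be far from indifferent to what it carries: 2-methoxyphenoxy in place of cyclohexylmethyl gives a 14-fold higher number from compound 2 to compound 3 (1.14 log units; beyond the scatter), and the same group in place of benzyl gives a 14-fold higher number from compound 1 to compound 3 (1.14 log units; beyond the scatter). Compound 1 also has an aromatic ring in this group, so an aromatic ring alone does not set compound 3 apart, whereas the two hydrogen-bond acceptors counted in the entering group are absent from both groups it replaces. Nothing measured here explains the jump.

Compound 3 differs from compound 1 in both the oxygen link and the methoxy on the ring, so the compounds shown cannot say which of them goes with the step. Plain phenoxy would separate the two, and how an amine at this carbon would compare also stays open.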